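A few compounds are considered here, and "the series" means these few. Any claim that something is new, unique, unknown or untested is made for them only; others in the source may bear on it.

Measured in an ADME assay on the whole organism (Rattus norvegicus, strain Sprague-Dawley) for pharmacokinetics, read by LC-MS, with a stated time of 30 min; a lower number here means that more of the compound stays in the plasma, a higher number that more of the compound sits outside the plasma:
Compound 1 `N#Cc1ccc(O[C@H]2CN(S(=O)(=O)c3ccc(Cl)cc3Cl)C[C@@]2(O)CO)cc1F`: 3.2 L/kg
Compound 2 `N#Cc1ccc(O[C@H]2CN(S(=O)(=O)c3ccc(C(F)(F)F)cc3C#N)C[C@@]2(O)CO)cc1F`: 3.6 L/kg
Compound 3 `N#Cc1ccc(O[C@H]2CN(S(=O)(=O)c3ccccc3C#N)C[C@@]2(O)CO)cc1F`: 0.9 L/kg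

Of these three, compound 3 has the lowest number in this assay. Compound 4 `N#Cc1ccc(O[C@H]2CN(S(=O)(=O)c3ccc(C(F)(F)F)nc3)C[C@@]2(O)CO)cc1F` differs from it in one place, with 6-(trifluoromethyl)pyridin-3-yl in place of 2-cyanophenyl on a sulfonyl sulfur.

Within the data shown here, two measured steps bear on this change, and both arrive at compound 3. The first is a 3.6-fold lower number from compound 1 to compound 3 (0.55 log units; beyond the scatter), which brings in the same 2-cyanophenyl group that compound 4 gives up. The second is a 4.0-fold lower number from compound 2 to compound 3 (0.60 log units; beyond the scatter), which loses a trifluoromethyl group of the kind that compound 4 carries. Both suggest a move back up, but neither measures this exact change. Among the measured compounds shown here, no measured compound has an aromatic ring with a hetero atom on the sulfonyl sulfur, so a full return is not assumed.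

The expected change is a 2.2-fold higher number from compound 3 to compound 4 (0.35 log units; beyond the scatter), smaller than either measured step. Compound 4 is estimated at 2 L/kg, with an expected range of 1 L/kg to 4 L/kg.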

Compound 4, volume of distribution at steady state: 4.1 L/kg
Compound 4: the middle estimate sits 2.1-fold (0.31 log units) below what was measured; measured number above the stated range.
By their numbers in this assay, from the lowest: compound 3; then compounds 1, 2 and 4 (each within the scatter of the next).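

In this assay, among these compounds, an aromatic ring with a hetero atom stands on the sulfonyl sulfur for the first time, and replacing 2-cyanophenyl with 6-(trifluoromethyl)pyridin-3-yl gives a 4.6-fold higher number from compound 3 to compound 4 (0.66 log units; beyond the scatter). Set against 2,4-dichlorophenyl, the same group gives a 1.3-fold higher number from compound 1 to compound 4 (0.11 log units; within the scatter), so these two groups cannot be told apart here, and compound 3 alone stays at the low end among the four compounds. Nothing available accounts for this result.

Because the ring and its substituent change together from compound 3 to compound 4, the compounds shown do not separate the part played by the ring hetero atom from that of the trifluoromethyl group or the nitrile. They also leave open where a plain phenyl, or a pyridine ring carrying an amine or a carboxylic acid, would fall on this sulfonyl sulfur.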